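The source may report more compounds than this note shows. Statements on the series, on what has been measured and on what is new or still open speak of the compounds shown alone.

Four compounds share one core, and three of them have been measured in a functional assay on U2OS cells for antagonist activity at proto-oncogene Wnt-3 (Homo sapiens), read by a luciferase reporter, with a stated time of 18 h; a higher number here means that more compound is needed for the effect, a lower number that less compound is needed. Compound 1 `CN(C)CC(=O)N1CCC(NS(=O)(=O)c2cc(S(=O)(=O)c3ccccc3)ccc2C(F)(F)F)CC1` gives 280 nM in this assay. Compound 2 `CC(C)(C)OC(=O)N1CCC[C@H]1C(=O)N1CCC(NS(=O)(=O)c2cc(S(=O)(=O)c3ccccc3)ccc2C(F)(F)F)CC1` gives 60 nM, and the change between them is a 4.7-fold lower number from compound 1 to compound 2 (0.67 log units; beyond the scatter). Compound 3 `CN(C)c1ccc(C(=O)N2CCC[C@H]2C(=O)N2CCC(NS(=O)(=O)c3cc(S(=O)(=O)c4ccccc4)ccc3C(F)(F)F)CC2)cc1` gives 830 nM, the highest of the three numbers shown: compound 1 stands nearest below it and compound 2 furthest below it, the latter gap being a 14-fold higher number from compound 2 to compound 3 (1.14 log units; beyond the scatter).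

Compound 4 `O=C([C@@H]1CCCN1C(=O)N1CCOCC1)N1CCC(NS(=O)(=O)c2cc(S(=O)(=O)c3ccccc3)ccc2C(F)(F)F)CC1` has not yet been measured. It differs from compound 3 by morpholin-4-yl in place of 4-(dimethylamino)phenyl on a carbonyl carbon. The measured step that bears most directly on this change is a 14-fold higher number from compound 2 to compound 3 (1.14 log units; beyond the scatter), which altered the same carbonyl carbon and showed that placing 4-(dimethylamino)phenyl there raised the number strongly. The change to compound 4 removes that aromatic ring again and puts a six-membered non-aromatic ring with two hetero atoms in its place. Compound 4 is therefore expected to move back toward the number of compound 2, though not necessarily the whole way. The expected step is a 5.5-fold lower number from compound 3 to compound 4 (0.74 log units; beyond the scatter). The estimate for compound 4 in this assay is 150 nM, with a range from 50 nM to 500 nM.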

Compound 4, half-maximal effective concentration: 280 nM
Estimate against measurement, compound 4: 1.9-fold (0.27 log units) below; measured number inside the range.
By their numbers in this assay, from the lowest: compound 2; then compounds 1 and 4 (each within the scatter of the next); then compound 3.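

On the carbonyl carbon whose other neighbour is the amide-type nitrogen in a ring, morpholin-4-yl in place of 4-(dimethylamino)phenyl gives a 3.0-fold lower number from compound 3 to compound 4 (0.47 log units; beyond the scatter), so the rise that came with the aromatic group is only partly undone. The further step, a 4.7-fold higher number from compound 2 to compound 4 (0.67 log units; beyond the scatter), shows that morpholin-4-yl does not match tert-butoxy here, and the three groups on this carbonyl carbon now stand in a clear order in this assay, with tert-butoxy lowest, morpholin-4-yl in the middle and 4-(dimethylamino)phenyl highest. No measurement is at hand that explains this order.

With only three groups at this place, the compounds shown leave open whether the low number of compound 2 belongs to the oxygen link of the tert-butoxy group or to its branched carbon chain. A methoxy group, an open-chain dimethylamino group or a piperidin-1-yl ring on the same carbonyl carbon would help separate these readings, and would also test whether the oxygen in the morpholin-4-yl ring matters to the number.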